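The source may hold more compounds than are shown below. What is called first, only, known or untested is meant among the compounds shown, and "the series" means these compounds.

Compound 1 `CCCCCCCC/C=C\CCCCCCCCOC[C@@H]1CCCN1C(=O)OC(C)(C)C`: > 100000 nM
Compound 2 `CCCCCCCC/C=C/CCCCCCCCOC[C@@H]1CCCN1C(=O)OC(C)(C)C`: > 100000 nM

In a functional assay on BXPC-3 cells (Homo sapiens) for inhibition, read by XTT assay, with a stated time of 72 h (a lower number here means a stronger inhibitor, a higher number a weaker inhibitor), compound 1 gives > 100000 nM, which is a limit and not a number. Compound 2 gives > 100000 nM, also a limit. For the measured compounds named here, the only measured step, a step that the two limits leave unreadable from compound 1 to compound 2, comes with the fact that compounds 1 and 2 differ only in the configuration as drawn, so it does not bear on the change made in compound 3 `CCCCCCCC/C=C\CCCCCCCCOC[C@@H]1CCCN1C(=O)CN`. There, aminomethyl in place of tert-butoxy on a carbonyl carbon: aminomethyl stands in place of tert-butoxy on a carbonyl carbon. Going by the values given here, no measured step covers this change, so a move towards stronger inhibition is expected only tentatively, as an at least 4.0-fold lower number from compound 1 to compound 3 (0.60 log units; beyond the scatter). Compound 3 is expected at 25000 nM, with an estimated range of 6000 nM to 100000 nM.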

Compound 3, half-maximal inhibitory concentration: 5300 nM
The estimate for compound 3 lay 4.7-fold (0.67 log units) above the measured number; the whole stated range lies above it.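

For the compounds shown here, at this carbonyl carbon, the change from tert-butoxy to aminomethyl gives the first readable number in this assay, with an at least 18-fold lower number from compound 1 to compound 3 (1.27 log units; beyond the scatter) as its step. Going by these compounds alone, compound 1 stands at a limit, so this step has a bound and no exact size, and the series so far gives only one number to set against that limit: the limit of > 100000 nM in this assay, at which 2 of the 3 values shown sit.

The compounds shown leave open whether hydroxymethyl or dimethylaminomethyl on the same carbonyl carbon would serve as aminomethyl does. They also leave open how aminomethyl behaves with the E double bond of compound 2.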